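Series notes: step from compound 3 to compound 4

The compounds below may be only part of what the source reports. "The series", "measured", "known", "first", "only" and "open" are said of these compounds alone.

Measured in an ADME assay on cells for inhibition of cytochrome P450 11B1, mitochondrial (Homo sapiens), read by HPLC, with a stated time of 60 min; on this read-out higher numbers stand for weaker inhibition and lower numbers for stronger inhibition:
compound 1, `Fc1ccc2nc(-n3ccnn3)n(C3CC3)c2c1`: 9070 nM
compound 2, `Fc1ccc2nc(-c3ccnnc3)n(C3CC3)c2c1`: > 10000 nM, a limit of the assay
compound 3, `CC(C)c1ncncc1-c1nc2cc(F)c(F)cc2n1C1CC1`: 1910 nM

Compound 3 gives the lowest of the two numbers shown; its nearest neighbour is compound 1, and that gap lies beyond the usual scatter. For compound 2 only a limit is known (the limit of > 10000 nM in this assay, at which 1 of the 3 values shown sits).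

Compound 4, `Fc1cc2nc(-c3cncnc3NCCC(F)(F)F)n(C3CC3)c2cc1F`, differs from compound 3 by (3,3,3-trifluoropropyl)amino in place of isopropyl on an aromatic carbon. For the measured compounds named here, the single measured step, an at least 1.1-fold higher number from compound 1 to compound 2 (0.04 log units; that floor lies within the scatter), exchanges one ring for another on the shared core and rests on a limit, so it says little about this change. Going by the values given here, no measured step swaps isopropyl for (3,3,3-trifluoropropyl)amino, and no pair among compounds 1 to 3 carries that group. The expected step of a 1.0-fold higher number from compound 3 to compound 4 (0.02 log units; within the scatter) is therefore set near no change, with a wide range in both directions. Compound 4 is estimated at 2000 nM in this assay, between 400 nM and 9000 nM.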

Compound 4, half-maximal inhibitory concentration: 378 nM
For compound 4 the middle estimate is 5.3-fold (0.72 log units) above the measured one; the whole stated range lies above it.
By their numbers in this assay, from the lowest: compound 4; then compound 3; then compound 1. At a limit, above all of these: compound 2.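

In this assay, the exchange on this aromatic carbon, next to the ring nitrogen and ortho to a large group, gives a 5.1-fold lower number from compound 3 to compound 4 (0.70 log units; beyond the scatter). For the compounds shown here, the only earlier step swapped one ring for another on the shared core and rested on a limit, so this is the first readable change in a group on the six-membered aromatic ring with 2 nitrogen, and the larger amino-linked chain goes with stronger inhibition rather than weaker. Nothing measured here accounts for the change in number.

As far as these compounds go, whether the change follows the amino link or the three fluorines stays open: propylamino and 3,3,3-trifluoropropoxy groups on this carbon would separate the two. From the compounds shown here alone, how a shorter chain such as methylamino or a cyclic amine such as morpholine reads here is also open.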